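The compounds below may be only part of what the source reports. "The series", "measured", "known", "first", "only" and "open" are said of these compounds alone.

In an in vitro functional assay on cells for antagonist activity at B1 bradykinin receptor (Homo sapiens), read by luminescence and calcium flux, with a stated time of 2 h (on this read-out lower numbers stand for stronger inhibition and higher numbers for weaker inhibition), compound 1 `Cc1ccc(S(=O)(=O)N2C=CNC(=O)[C@H]2CC(=O)N[C@@H]2CCCc3ccccc32)cc1` gives 3.3 nM. Compound 2 `Cc1ccc(S(=O)(=O)N2C=CNC(=O)[C@H]2CC(=O)N[C@@H]2CCc3ccccc32)cc1` gives 94.7 nM, and compound 3 `Cc1ccc(S(=O)(=O)N2C=CNC(=O)[C@H]2CC(=O)NC2CCNc3ccccc32)cc1` gives 21.6 nM. Among these three numbers compound 3 stands second highest: the step of a 4.4-fold lower number from compound 2 to compound 3 (0.64 log units; beyond the scatter) separates it from compound 2, and the step of a 6.5-fold higher number from compound 1 to compound 3 (0.82 log units; beyond the scatter) separates it from compound 1. Compound 4 `Cc1ccc(S(=O)(=O)N2C=CNC(=O)[C@H]2CC(=O)NC2CCC(C)CC2)cc1` differs from compound 3 in one place: a group of 7 heavy atoms (7 carbon; one six-membered non-aromatic ring of carbon only) in place of a group of 10 heavy atoms (9 carbon, 1 nitrogen; one six-membered non-aromatic ring with 1 hetero atom, one six-membered aromatic ring of carbon only), on an amide-type nitrogen. Among the measured compounds shown here, two measured steps bear on this position. The step of a 29-fold higher number from compound 1 to compound 2 (1.46 log units; beyond the scatter) shows that a smaller non-aromatic ring in this place goes with a much higher number, and the step of a 6.5-fold higher number from compound 1 to compound 3 (0.82 log units; beyond the scatter) shows that exchanging one ring atom also goes with a higher number. The change to compound 4 removes the aromatic ring entirely, a larger alteration than either measured step, so a rise in this assay beyond the scatter is expected. On that basis the expected step is a 14-fold higher number from compound 3 to compound 4 (1.14 log units; beyond the scatter). For compound 4 the estimated value in this assay is 300 nM, with a range from 60 nM to 2000 nM.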

Compound 4, half-maximal inhibitory concentration: 314 nM
Beside the measured number, compound 4's estimate is 1.0-fold (0.02 log units) below it; measured number inside the range.
By their numbers in this assay, from the lowest: compound 1; then compound 3; then compound 2; then compound 4.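

With 4-methylcyclohexyl on the amide-type nitrogen, the number rises beyond the scatter against each of the three fused-ring groups (a 15-fold higher number from compound 3 to compound 4 (1.16 log units; beyond the scatter); a 3.3-fold higher number from compound 2 to compound 4 (0.52 log units; beyond the scatter); a 95-fold higher number from compound 1 to compound 4 (1.98 log units; beyond the scatter)). Of the four compounds, compound 4 alone carries no aromatic ring in this group, and it has the highest number, so a non-aromatic six-membered ring on this nitrogen does not keep the low numbers of the fused-ring groups. Nothing measured here accounts for the rise.

On these data alone, what remains open is which feature of the change goes with the rise: the loss of the aromatic ring or the presence of the methyl group. A plain cyclohexyl or a benzyl group on the same nitrogen would help to separate the two.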